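Prop-1-en-1-yl in place of butyl: working notes

The compounds below may be only part of what the source reports. "The series", "measured", "known", "first", "only" and "open" are said of these compounds alone.

Measured so far in a functional assay (aorta) with Oryctolagus cuniculus as the target; on this read-out lower numbers stand for tighter binding and higher numbers for weaker binding:
- compound 1 `Cc1ccnc2c1nc(C1CC1)n2Cc1cc(Cl)c(O)c(Cl)c1` gives 2 nM
- compound 2 `CCCc1nc2c(C)ccnc2n1Cc1ccc(-c2ccccc2C(=O)O)cc1` gives 3.16 nM; 3.16 nM (2 entries)
- compound 3 `CCCCc1nc2c(C)ccnc2n1Cc1ccc(-c2ccccc2C(=O)O)cc1` gives 7.94 nM

Compound 3 (7.94 nM) carries a higher number than compound 1 (2 nM), a gap beyond the scatter. Compound 4 `C/C=C/c1nc2c(C)ccnc2n1Cc1ccc(-c2ccccc2C(=O)O)cc1` has prop-1-en-1-yl in place of butyl on an aromatic carbon. Within the data shown here, no step between measured compounds is available as a guide. The nearest reference is the propyl chain of compound 2 (3.16 nM; 3.16 nM (2 entries)). The expected step of a 1.6-fold lower number from compound 3 to compound 4 (0.20 log units; within the scatter) in this assay is small, towards a lower number, and not beyond the scatter. For compound 4 the estimated value is 5 nM (expected range 1.6 nM to 16 nM).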

Compound 4, dissociation constant: 5.01 nM
For compound 4 the middle estimate is 1.0-fold (0.00 log units) below the measured one; measured number inside the range.
By their numbers in this assay, from the lowest: compound 1; then compounds 4 and 3 (each within the scatter of the next).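

Prop-1-en-1-yl in place of butyl on this aromatic carbon gives (a 1.6-fold lower number from compound 3 to compound 4 (0.20 log units; within the scatter)) in this assay. This position therefore accepts a chain with a double bond outside aromatic rings, and the read-out gives no separation between that chain and butyl. Nothing on hand explains this result.

Still open, as far as these compounds go, is whether a chain carrying oxygen, such as methoxymethyl, or an amine on this carbon would stay within the scatter of these chains. The same question applies to a longer chain such as pentyl.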